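This account rests on a few compounds, and the source may have more. Where it says the series, first, only, none or still open, it means among the compounds named here.

Working notes on the series. Compound 1 `O=S(=O)(NC1=NCCN1C(=S)SN1CCn2c1nsc2=S)c1ccc(OC(F)(F)F)cc1` and compound 2 `CC(=O)Nc1ccc(S(=O)(=O)NC2=NCCN2C(=S)SN2CCn3c2nsc3=S)cc1` share one core and differ at a single aromatic carbon. In a functional assay on KYSE-510 cells (Homo sapiens) for antiproliferative activity, read by crystal violet staining, with a stated time of 96 h (a higher number here means a weaker inhibitor of growth, a lower number a stronger inhibitor of growth), compound 1 gives >= 20000 nM, a limit of the assay and not a number. In this assay compound 2 likewise gives >= 20000 nM, again a limit. The step that the two limits leave unreadable from compound 1 to compound 2 is therefore unreadable, since both ends sit at the limit of >= 20000 nM in this assay, at which 2 of the 2 values shown sit. Compound 2 thus stands only at the limit, with no numerical value on either side of it. Compound 3 `O=S(=O)(NC1=NCCN1C(=S)SN1CCn2c1nsc2=S)c1ccc(-c2ccccc2)cc1` carries the change (phenyl in place of acetamido on an aromatic carbon). Going by the values given here, the one measured step bears on this change only in showing that neither of its ends fell below the limit; its size is not readable. No step beyond the scatter can be foreseen from this. Compound 3 is therefore expected to sit at or near the same limit, with an estimated step that the limit leaves unreadable from compound 2 to compound 3. The estimate for compound 3 is 30000 nM, in a range from 10000 nM to 100000 nM, most likely reported only as a limit.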

Compound 3, concentration for 50% growth inhibition: >= 20000 nM
Compound 3 was reported as a limit (the forecaster's own chance of this, stated with the estimate: 75%); the middle value does not contradict the limit.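

No step can be read among compound 1, compound 2 and compound 3, since all three stop at one limit of the assay and give no number: the limit of >= 20000 nM in this assay, at which 3 of the 3 values shown sit. The compounds shown leave open how trifluoromethoxy, acetamido and phenyl rank in this assay, and whether any group on this aromatic carbon gives a measurable value.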